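Cytotoxicity limits and a benzyl swap on a shared core

This account rests on a few compounds, and the source may have more. Where it says the series, first, only, none or still open, it means among the compounds named here.

Compound 1 `Nc1cc(N)c2nc(-c3ccccc3)c(NCc3ccc(Cl)c(Cl)c3)nc2c1` carries a 3,4-dichlorobenzyl group on a saturated chain carbon bound to a nitrogen on an aromatic ring. In a functional assay on HCT-15 cells (Homo sapiens) for inhibition, read by sulforhodamine B assay, with a stated time of 48 h (a higher number here means that more compound is tolerated, a lower number that less compound is tolerated), compound 1 gives only the limit < 100000 nM, not a number. Compound 2 `CCOC(=O)[C@H](CCC(=O)O)NC(=O)c1ccc(Sc2nc3cc(N)cc(N)c3nc2-c2ccccc2)cc1` likewise reaches only the limit < 100000 nM in this assay. Compound 3 `CCOC(=O)[C@H](CCC(=O)O)NC(=O)c1ccc(Oc2nc3cc(N)cc(N)c3nc2-c2ccccc2)cc1` also stops at the limit < 100000 nM. Compound 1 thus stands where every value shown stands, at the limit of < 100000 nM in this assay, at which 3 of the 3 values shown sit. Compound 4 `COc1ccc(CNc2nc3cc(N)cc(N)c3nc2-c2ccccc2)cc1` differs from compound 1 by 4-methoxyphenyl in place of 3,4-dichlorophenyl on a saturated chain carbon bound to a nitrogen on an aromatic ring. Going by the values given here, with no measured step to draw on, the expectation is no change beyond the usual scatter, and the step from compound 1 to compound 4 is estimated at a step that the limit leaves unreadable from compound 1 to compound 4. Compound 4 is expected to give 40000 nM, within a range of 8000 nM to 100000 nM.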

Compound 4, concentration lethal to 50% of the cells: 75900 nM
For compound 4 the middle estimate is 1.9-fold (0.28 log units) below the measured one, and the stated range covers the measured number.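

Compound 1 is held only as a limit in this assay, and no size can be read for the step to compound 4. The compounds shown leave open how 3,4-dichlorobenzyl and 4-methoxybenzyl truly compare in this assay.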